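Compound 3: an estimate starting from a limit

This account rests on a few compounds, and the source may have more. Where it says the series, first, only, none or still open, it means among the compounds named here.

- Compound 1 `Cc1ccccc1S(=O)(=O)NC(=O)C(C)(Cc1ccc(Cl)cc1)Oc1ccc(C(C)C)cc1`: > 10 mg/kg
- Compound 2 `COc1ccc(S(=O)(=O)NC(=O)C(C)(Cc2ccc(Cl)cc2)Oc2ccc(C(C)C)cc2)cc1`: > 10 mg/kg

In a functional assay on the whole organism for inhibition, with Rattus norvegicus as the target (on this read-out lower numbers stand for an effect already at smaller amounts and higher numbers for an effect only at larger amounts of compound), compound 1 gives > 10 mg/kg, which is a limit and not a number. Compound 2 gives > 10 mg/kg, also a limit. Compound 3 `CC(C)c1ccc(OC(C)(Cc2ccc(Cl)cc2)C(=O)/N=C(\N)NO)cc1` has not been measured and carries a group of 5 heavy atoms (1 carbon, 3 nitrogen, 1 oxygen; no ring) in place of a group of 11 heavy atoms (7 carbon, 1 nitrogen, 2 oxygen, 1 sulfur; one six-membered aromatic ring of carbon only), on a carbonyl carbon. Going by the values given here, the only measured step, a step that the two limits leave unreadable from compound 1 to compound 2, has no readable size and concerns a group that compound 3 loses entirely, so it gives no guide to direction. The expected step is a step that the limit leaves unreadable from compound 1 to compound 3, with no direction supported by the data. For compound 3 the estimated value is 12 mg/kg, with an expected range of 3 mg/kg to 50 mg/kg.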

Compound 3, dose for half-maximal effect: 10 mg/kg
For compound 3 the middle estimate is 1.2-fold (0.08 log units) above the measured one; measured number inside the range.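

In this assay, replacing the ((2-methylphenyl)sulfonyl)amino group on the carbonyl carbon with a smaller group without a ring gives a number no higher from compound 1 to compound 3 (the limit leaves the size open). This position therefore does not need that aromatic ring or the sulfur for a dose to be read as a number. The size of the step cannot be read, because the value of compound 1 is only a limit: the limit of > 10 mg/kg in this assay, at which 2 of the 3 values shown sit.

On these data alone, it remains open how a carboxylic acid or a simple amine on this carbonyl carbon would compare with compound 3.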